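Swapping Phenyl for Pyridin-2-yl: Compound 3 to Compound 4

This account rests on a few compounds, and the source may have more. Where it says the series, first, only, none or still open, it means among the compounds named here.

Compound 1, `CC(=O)c1coc(C(=O)CCCCCCc2ccccc2)n1`, gives 123 nM in an assay on HEK-293T cells for inhibition of diacylglycerol lipase-alpha (Homo sapiens), read by colorimetric assay; a lower number here means a stronger inhibitor, a higher number a weaker inhibitor.
Compound 2, `O=Cc1coc(C(=O)CCCCCCc2ccccc2)n1`, gives 1510 nM in this assay.
Compound 3, `O=C(CCCCCCc1ccccc1)c1nc(-c2ccccc2)co1`, gives 8710 nM in this assay.

Among these three, compound 3 gives the highest number, so it is the weakest inhibitor in this assay. Its nearest neighbour is compound 2, a step of a 5.8-fold higher number from compound 2 to compound 3 (0.76 log units; beyond the scatter), and its furthest is compound 1, a step of a 71-fold higher number from compound 1 to compound 3 (1.85 log units; beyond the scatter). Both measured steps onto compound 3 replace a carbonyl-bearing group with phenyl on the shared core and both raise the number; the third step, a 12-fold higher number from compound 1 to compound 2 (1.09 log units; beyond the scatter), exchanges methyl for hydrogen on a carbonyl carbon.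

Compound 4, `O=C(CCCCCCc1ccccc1)c1nc(-c2ccccn2)co1`, differs from compound 3 in one place: pyridin-2-yl in place of phenyl on an aromatic carbon. Going by the values given here, none of the measured steps changes one six-membered aromatic ring for another, so nothing here bears directly on this swap; what is known only places compound 3 at the weak end of the series. The step is therefore expected to be small, within or near the scatter, and in no firm direction, estimated as a 1.2-fold lower number from compound 3 to compound 4 (0.09 log units; within the scatter). Compound 4 is expected to give 7000 nM, in the range 2500 nM to 20000 nM.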

Compound 4, half-maximal inhibitory concentration: > 10000 nM
Compound 4 was reported as a limit; the forecaster's own chance of this, stated with the estimate: 10%; middle value at least 1.4-fold (0.15 log units) away from the limit.
By their numbers in this assay, from the lowest: compound 1; then compound 2; then compound 3. At a limit, above all of these: compound 4.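

Compound 4 stands in this assay only as a limit, not as a measured number: the limit of > 10000 nM in this assay, at which 1 of the 4 values shown sits. On the aromatic carbon next to the ring nitrogen, the change from phenyl to pyridin-2-yl brings no recovery of inhibition, with an at least 1.1-fold higher number from compound 3 to compound 4 (0.05 log units; that floor lies within the scatter); this floor alone does not separate the two compounds, so the result rules out a gain of any size but fixes no size of loss. Set against the two carbonyl-bearing groups at the same place, the new ring keeps the gap seen with phenyl, with an at least 6.6-fold higher number from compound 2 to compound 4 (0.82 log units; beyond the scatter) and an at least 81-fold higher number from compound 1 to compound 4 (1.91 log units; beyond the scatter), so both aromatic rings shown here fall well short of formyl and acetyl.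

Going by these compounds, how far compound 4 actually lies from compound 3 remains open, and the limit leaves the effect of the added ring nitrogen on inhibition unsettled. On these data alone, it is also open whether other carbonyl-bearing groups at this place, such as propanoyl, a methyl ester or a carboxylic acid, would extend the advantage of acetyl over formyl or lose it.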